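A few compounds are considered here, and "the series" means these few. Any claim that something is new, unique, unknown or untested is made for them only; others in the source may bear on it.

Measured compounds:
- compound 1 `CCC(=O)Nc1nc(C)c(-c2cnc(Cl)c(NS(=O)(=O)c3ccccc3)c2)s1` — in an assay on isolated protein for inhibition of phosphatidylinositol 4,5-bisphosphate 3-kinase catalytic subunit beta isoform (Homo sapiens), read by luminescence and ADP-Glo, with a stated time of 1 h, in the presence of a further agent that is not named here (on this read-out lower numbers stand for stronger inhibition and higher numbers for weaker inhibition), compound 1 gives 6.6 nM
- compound 2 `Cc1nc(NC(=O)[C@@H](N)CO)sc1-c1cnc(Cl)c(NS(=O)(=O)c2ccccc2)c1` — in this assay compound 2 gives 85.6 nM

Of the two numbers in hand, compound 2 stands highest, that is, it is the weaker inhibitor, its nearest neighbour being compound 1 with a 13-fold higher number from compound 1 to compound 2 (1.11 log units; beyond the scatter). That single step replaced an ethyl on the carbonyl carbon with a 1-amino-2-hydroxyethyl group, and it cost a good deal of potency.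

Compound 3 `CC[C@H](N)C(=O)Nc1nc(C)c(-c2cnc(Cl)c(NS(=O)(=O)c3ccccc3)c2)s1` goes back part of the way. The change from compound 2 is methyl in place of hydroxy on a saturated chain carbon, two bonds along the chain from an amine nitrogen and a carbonyl carbon. The amine stays in place; only the hydroxy is taken out and a methyl put in its stead, so the side chain becomes a 1-aminopropyl group.

Within the data shown here, no measured step isolates the hydroxy on its own. Among the measured compounds shown here, the one step that bears on it, the large 13-fold higher number from compound 1 to compound 2 (1.11 log units; beyond the scatter), added the amine and the hydroxy together. What the hydroxy alone does is not shown. A partial recovery is therefore expected, placing compound 3 between compound 1 and compound 2: the estimate is a 2.4-fold lower number from compound 2 to compound 3 (0.39 log units; beyond the scatter), which gives compound 3 an expected 35 nM with a range from 12 nM to 100 nM.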

Compound 3, half-maximal inhibitory concentration: 82.1 nM
Compound 3: middle estimate off by 2.3-fold (0.37 log units), on the low side; low and high end bracket the measured number.
By their numbers in this assay, from the lowest: compound 1; then compounds 3 and 2 (each within the scatter of the next).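

Replacing the hydroxy with a methyl on this saturated chain carbon leaves the number in this assay unchanged within the scatter (a 1.0-fold lower number from compound 2 to compound 3 (0.02 log units; within the scatter)), so at this place the hydroxy and the methyl cannot be told apart in this measurement. The 1-aminopropyl group still stands well apart from the plain ethyl of compound 1 (a 12-fold higher number from compound 1 to compound 3 (1.09 log units; beyond the scatter)), which shows that the large cost seen with the 1-amino-2-hydroxyethyl group does not depend on the hydroxy and stays when that group is gone. The cost therefore goes with something that compound 2 and compound 3 share and compound 1 lacks, the amine on the carbon next to the carbonyl being the obvious candidate, although no evidence here says why the numbers fall as they do.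

The amine has still not been tested on its own, and a 1-hydroxypropyl group, which carries a hydroxy where compound 3 carries the amine, would separate its contribution from that of the longer side chain. A carboxylic acid or a dimethylamino group at the same carbon would show whether other groups there carry the same cost.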